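Extending the Side Chain from Compound 2 to Compound 4

This account rests on a few compounds, and the source may have more. Where it says the series, first, only, none or still open, it means among the compounds named here.

Of the compounds shown here, three sharing one core have been measured in an assay on CHO cells for displacement of a labelled ligand from adenosine receptor A3 (Homo sapiens), read by scintillation counting, tested at 1 uM; on this read-out higher numbers stand for more inhibition at the one concentration tested (going by the name of the read-out) and lower numbers for less inhibition. Compound 1 `CC(C)c1nc(N)c2nn(-c3ccccc3)cc2n1` carries an isopropyl group and gives 11%. Compound 2 `Nc1nc(Cc2ccccc2Cl)nc2cn(-c3ccccc3)nc12` carries a 2-chlorobenzyl group and gives 22%. Compound 3 `Nc1nc(/C=C/c2ccccc2)nc2cn(-c3ccccc3)nc12` carries a 2-phenylethenyl group and gives 25%. Compound 2 thus stands second highest of the three: the step of a number 3 percentage points higher from compound 2 to compound 3 (within the scatter) lies within the scatter, while a number 11 percentage points higher from compound 1 to compound 2 (beyond the scatter) lies beyond it.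

The unmeasured compound 4 `Nc1nc(CCCc2ccccc2)nc2cn(-c3ccccc3)nc12` differs from compound 2 in one place: phenethyl in place of 2-chlorophenyl on a saturated chain carbon bound to an aromatic carbon. Two kinds of measured step bear on this. Replacing isopropyl by either of the two measured groups raised the number, a number 11 percentage points higher from compound 1 to compound 2 (beyond the scatter) and a number 14 percentage points higher from compound 1 to compound 3 (beyond the scatter), whereas exchanging one of those groups for the other gave a number 3 percentage points higher from compound 2 to compound 3 (within the scatter). The move to compound 4 is again an exchange of one such group for another rather than a return to isopropyl, so the expected step is no change at the digits printed from compound 2 to compound 4 (within the scatter), within the scatter. Compound 4 is accordingly estimated at 22% in this assay, with a range from 6% to 38%.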

Compound 4, a percentage reported as inhibition, at one concentration (the size of the read-out at that concentration, not a potency): 12%
Compound 4: the middle estimate sits 10 percentage points above what was measured; the range from low to high includes it.
By their numbers in this assay, from the lowest: compounds 1, 4, 2 and 3 (each within the scatter of the next, the first and the last beyond it).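

In this assay, the exchange of 2-chlorophenyl for phenethyl on a saturated chain carbon bound to an aromatic carbon gives a number 10 percentage points lower from compound 2 to compound 4 (within the scatter), so this place accepts a group of 8 heavy atoms, all carbon, in place of one of 7 with a chlorine, without a step beyond the scatter. The earlier compounds had not shown that a group with a six-membered aromatic ring can also give a value close to that of the isopropyl group: compound 4 gives 12% and compound 1 gives 11%, so such a ring does not by itself secure a number apart from that of compound 1. Nothing available accounts for these values.

The single step changes the chain and removes the chlorine together, so the compounds shown cannot separate the two changes, and a phenethyl group with a chlorine on its ring would be needed to do so. They also leave open how this place responds to a longer chain or to a chain ending in an amine or a carboxylic acid.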